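The compounds below may be only part of what the source reports. "The series", "measured", "known", "first", "only" and "open" are said of these compounds alone.

Measured so far:

- compound 1 `CCOC(=O)c1c(O)c2cccnc2n(-c2ccccc2)c1=O`: in a functional assay on the whole organism for inhibition, with Rattus norvegicus as the target, read by cytopathic effect and paw edema, at a dose of 100 mg/kg by the oral route (on this read-out higher numbers stand for more inhibition at the one dose given (going by the name of the read-out) and lower numbers for less inhibition), compound 1 gives 15.5%
- compound 2 `O=C(Nc1ccccn1)c1c(O)c2cccnc2n(-c2ccccc2)c1=O`: compound 2 gives 14.6%
- compound 3 `O=C(Nc1ccncc1)c1c(O)c2cccnc2n(-c2ccccc2)c1=O`: compound 3 gives 24.3%

All three compounds share one core and differ only in the group carried on the carbonyl carbon. Compound 1, with its ethoxy group, sits within the scatter of both companions: the step of a number 0.9 percentage points lower from compound 1 to compound 2 (within the scatter) and the step of a number 8.8 percentage points higher from compound 1 to compound 3 (within the scatter) are each too small to count as a real change, as is the step of a number 9.7 percentage points higher from compound 2 to compound 3 (within the scatter) between the two amides.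

Compound 4 `O=C(NCc1cccnc1)c1c(O)c2cccnc2n(-c2ccccc2)c1=O` has not yet been measured. Its change from compound 1 is ((pyridin-3-yl)methyl)amino in place of ethoxy on a carbonyl carbon. The two measured steps that most resemble this one, from compound 1 to compound 2 and from compound 1 to compound 3, both swapped the ethoxy group for an amide carrying a pyridine ring and both stayed within the scatter. A third such swap is therefore expected to stay within the scatter as well, the step of a number 2.5 percentage points higher from compound 1 to compound 4 (within the scatter) being the estimate. Compound 4 is expected to give 18%, with a likely range from 5% to 32%.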

Compound 4, a percentage reported as inhibition, in the whole organism at one dose (the size of the read-out at that dose, not a potency): 14.7%
Estimate against measurement, compound 4: 3.3 percentage points above; low and high end bracket the measured number.
By their numbers in this assay, from the lowest: compounds 2, 4, 1 and 3 (each within the scatter of the next).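

Placing the larger ((pyridin-3-yl)methyl)amino group on the carbonyl carbon, with a methyl link between the amide nitrogen and the pyridine ring, gives no change that can be told from noise in this assay, the step being a number 0.8 percentage points lower from compound 1 to compound 4 (within the scatter). The comparisons with the amides that carry the ring directly on that nitrogen also stay small, with the step of a number 0.1 percentage points higher from compound 2 to compound 4 (within the scatter) and the step of a number 9.6 percentage points lower from compound 3 to compound 4 (within the scatter), so this read-out at a single dose does not separate the ethoxy group from any of the three amides. No measurement shown here bears on why this is so.

As far as these compounds go, it remains open whether a carboxylic acid at this carbonyl position would give a step beyond the scatter. A benzylamino group, which has a plain benzene ring in place of the pyridine, would test whether the ring nitrogen plays any part.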